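This account rests on a few compounds, and the source may have more. Where it says the series, first, only, none or still open, it means among the compounds named here.

In a functional assay on CCRF-CEM cells (Homo sapiens) for cytotoxicity, with a stated time of 72 h (a lower number here means a stronger inhibitor, a higher number a weaker inhibitor), compound 1 (`CCOC(=O)/C=C/C=C/C=C/c1ccc[nH]1`) gives 3670 nM, compound 2 (`CCOC(=O)/C=C/C=C/C=C/C=C/c1ccc[nH]1`) gives 1340 nM and compound 3 (`O=C(/C=C/C=C/C=C/c1ccc[nH]1)OCc1ccccc1`) gives 830 nM. Compound 3 and compound 2 are level, since their values lie within the usual scatter of repeated measurements, while compound 1 stands clearly higher. That gap is a 4.4-fold lower number from compound 1 to compound 3 (0.65 log units; beyond the scatter), and it comes with phenyl in place of methyl.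

Compound 4 (`O=C(/C=C/C=C/C=C/C=C/c1ccc[nH]1)OCc1ccccc1`) keeps the phenyl of compound 3 and differs from it in one place: 2-(1H-pyrrol-2-yl)ethenyl in place of 1H-pyrrol-2-yl on a double-bonded chain carbon bound to a double-bonded chain carbon.

For the measured compounds named here, no measured step shows this change on a phenyl-bearing compound. The closest evidence is that compound 1 and compound 2 differ from each other by the same change, and the values of that pair show a lower number for compound 2 at 1340 nM than for compound 1 at 3670 nM. One pair is thin support, and nothing yet shows whether the change adds to the phenyl swap. In this assay a move towards a lower number is therefore expected, of modest size. The expected change is a 2.1-fold lower number from compound 3 to compound 4 (0.32 log units; beyond the scatter). For compound 4 the estimated value is 400 nM, with an expected range from 150 nM to 1000 nM.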

Compound 4, half-maximal inhibitory concentration: 190 nM
The estimate for compound 4 lay 2.1-fold (0.32 log units) above the measured number; the measured number falls inside the stated range.
By their numbers in this assay, from the lowest: compound 4; then compounds 3 and 2 (each within the scatter of the next); then compound 1.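

For the compounds shown here, compound 4 gives the first reading of 2-(1H-pyrrol-2-yl)ethenyl in place of 1H-pyrrol-2-yl on a phenyl-bearing compound in this assay, a 4.4-fold lower number from compound 3 to compound 4 (0.64 log units; beyond the scatter), so the lower number is no longer tied to the methyl-bearing pair, compound 1 at 3670 nM and compound 2 at 1340 nM. Going by these compounds alone, compound 4 also gives the first reading of phenyl in place of methyl on the longer chain, a 7.1-fold lower number from compound 2 to compound 4 (0.85 log units; beyond the scatter). Together these answer the question of whether the two changes add up: in these four compounds they do, with the phenyl change keeping much the same size whichever chain it is placed on: the same change on two cores in this assay, a 4.4-fold lower number (0.65 log units; beyond the scatter) from compound 1 to compound 3 and a 7.1-fold lower number (0.85 log units; beyond the scatter) from compound 2 to compound 4, 1.6-fold (0.20 log units) apart, within the scatter of two such steps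

As far as these compounds go, four compounds cannot show how far this trend runs, so it remains open whether a longer chain, with one more ethenyl unit, would lower the number again or reverse it. From the compounds shown here alone, it is also open whether the ester is needed at all, since a carboxylic acid or an amide in its place, or a fluorine or an amine on the phenyl ring, would test parts of the molecule that stay unchanged across this set.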